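This account rests on a few compounds, and the source may have more. Where it says the series, first, only, none or still open, it means among the compounds named here.

Going by the values given here, in a physicochemical assay for solubility, measured as kinetic solubility, with a stated time of 1 h, at pH 7.4 (a lower number here means a less soluble compound, a higher number a more soluble compound), compound 1 (`O=C(NC1=NN(c2ccc(Cl)c(Cl)c2)CC1)c1ccccn1`) reads 11000 nM and compound 2 (`O=C(NC1=NN(c2ccc(Cl)c(Cl)c2)CC1)c1ccncn1`) reads 13000 nM so compound 2 stands level with its only neighbour. Among the compounds with values here, the single measured step (a 1.2-fold higher number from compound 1 to compound 2 (0.07 log units; within the scatter)) puts pyrimidin-4-yl in place of pyridin-2-yl on a carbonyl carbon and stays within the scatter. Compound 3 (`O=C(NC1=NN(c2ccc(Cl)c(Cl)c2)CC1)c1ccnnc1`) carries pyridazin-4-yl in place of pyrimidin-4-yl on a carbonyl carbon. Within the data shown here, with only that small step (a 1.2-fold higher number from compound 1 to compound 2 (0.07 log units; within the scatter)) as a guide, no shift beyond the scatter is expected in this assay for this exchange, and the expected step (a 1.1-fold higher number from compound 2 to compound 3 (0.03 log units; within the scatter)) is small. For compound 3 the estimate is 14000 nM with 7000 nM to 28000 nM as its expected range.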

Compound 3, solubility: 23000 nM
Estimate against measurement, compound 3: 1.6-fold (0.22 log units) below; low and high end bracket the measured number.
By their numbers in this assay, from the lowest: compounds 1, 2 and 3 (each within the scatter of the next, the first and the last beyond it).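

In this assay moving from pyrimidin-4-yl to pyridazin-4-yl on a carbonyl carbon, with the same atoms joined differently, gives a 1.8-fold higher number from compound 2 to compound 3 (0.25 log units; within the scatter) and so leaves the two compounds level. Replacing pyridin-2-yl with pyridazin-4-yl at this place gives a 2.1-fold higher number from compound 1 to compound 3 (0.32 log units; beyond the scatter) and is the only step shown that lies beyond the scatter, though only modestly. Nothing available explains this result. Still open, on these data alone, is how an aliphatic amine or a carboxylic acid would read at this place in this assay and whether such groups would take the number further from these three.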